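From a Propyl Acid to a Hydroxymethyl Amide

The source may hold more compounds than are shown below. What is called first, only, known or untested is meant among the compounds shown, and "the series" means these compounds.

Measured compounds:
- compound 1, `C[C@]1(C(=O)O)CC[C@H](C(=O)N2CC[C@](c3ccc(C(F)(C(F)(F)F)C(F)(F)F)cc3)(S(=O)(=O)c3ccc(F)cc3)C2)CC1`: 93%
- compound 2, `CC[C@]1(C(=O)O)CC[C@H](C(=O)N2CC[C@](c3ccc(C(F)(C(F)(F)F)C(F)(F)F)cc3)(S(=O)(=O)c3ccc(F)cc3)C2)CC1`: "not determined" (no result reported)
- compound 3, `CCC[C@]1(C(=O)N2CC[C@](c3ccc(C(F)(C(F)(F)F)C(F)(F)F)cc3)(S(=O)(=O)c3ccc(F)cc3)C2)CC[C@H](C(=O)O)CC1`: "not determined" (no result reported)

Compound 1 was run in an ADME assay on microsomes from liver (Mus musculus) for metabolic stability, with a stated time of 10 min (a higher number here means that more of the compound is left, a lower number that less of the compound is left), and gives 93%. Compound 2 and compound 3 were not measured there, so no number stands beside either of them, and nothing can be said about how compound 3 compares with compound 1 or compound 2 on this read-out. Within the data shown here, compound 3 is therefore a starting point without a value of its own; the only number among the three is the one for compound 1 in this assay.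

Compound 4, `O=C([C@H]1CC[C@H](CO)CC1)N1CC[C@](c2ccc(C(F)(C(F)(F)F)C(F)(F)F)cc2)(S(=O)(=O)c2ccc(F)cc2)C1`, is the next compound to be measured. It differs from compound 3 at a carbonyl carbon whose other neighbour is an amide-type nitrogen in a ring: 4-(hydroxymethyl)cyclohexyl in place of 4-carboxy-1-propylcyclohexyl on a carbonyl carbon.

Among the measured compounds shown here, no step between two measured compounds exists that would show how this assay responds to a change of this kind. With compound 3 unmeasured, no direction can be read from the data; the expectation below rests only on compound 1, for which 93% is the single anchor. Compound 4 is expected to sit somewhat lower than that anchor, with a step in the direction of less remaining compound that may reach beyond the usual scatter.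

For compound 4 in this assay the estimate is 65%, with a range from 35% to 90%.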

Compound 4, percent of the compound remaining: 63%
The estimate for compound 4 lay 2 percentage points above the measured number; measured number inside the range.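

In this assay the series now has its first readable step, a number 30 percentage points lower from compound 1 to compound 4 (beyond the scatter) with 4-(hydroxymethyl)cyclohexyl in place of 4-carboxy-4-methylcyclohexyl on the carbonyl carbon. The earlier compounds shown here offered a single number and could show no response at all, whereas this pair shows that the read-out moves with the group at this position while the shared core stays the same. Nothing measured here explains the drop.

Steps that start from compound 2 or compound 3 cannot be read, so the part played by the propyl chain in compound 3 stays unknown. Among these compounds, the single change from compound 1 to compound 4 also swaps the carboxylic acid for hydroxymethyl and removes the methyl together, which leaves open how much of the step belongs to each, and how a 4-carboxycyclohexyl or a 4-(aminomethyl)cyclohexyl on the same carbonyl carbon would read.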